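Replacing One Ring Substituent: Acid Dissociation Likely Steady

The source may hold more compounds than are shown below. What is called first, only, known or untested is meant among the compounds shown, and "the series" means these compounds.

Of the compounds shown here, three built on one shared core have been measured in a physicochemical assay for acid dissociation. Compound 1 `COc1cccc(CNCCCNc2ccnc3cc(-c4ccc(C(F)(F)F)cc4)ccc23)c1O` gives 9.47, compound 2 `COc1cccc(CNCCCNc2ccnc3cc(Cc4ccc(F)cc4)ccc23)c1O` gives 9.47, and compound 3 `COc1cccc(CNCCCNc2ccnc3cc(Oc4cccc(N(C)C)c4)ccc23)c1O` gives 9.28. Compound 3 has the lowest of the three numbers, yet both steps leading to it stay within the scatter: a number 0.19 log units lower from compound 1 to compound 3 (within the scatter) and a number 0.19 log units lower from compound 2 to compound 3 (within the scatter), while no change at the digits printed from compound 1 to compound 2 (within the scatter). On these numbers the three groups sitting on that aromatic carbon of the core cannot be told apart.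

Compound 4 `COc1ccc(-c2ccc3c(NCCCNCc4cccc(OC)c4O)ccnc3c2)cc1` is the next step from compound 3: 4-methoxyphenyl in place of 3-(dimethylamino)phenoxy on an aromatic carbon. Among the measured compounds shown here, the steps that bear on this change are the earlier swaps of a group at the same carbon, each of which remained within the scatter, so no step beyond the scatter is expected in this assay here either. The estimate for compound 4 is 9.4, expected to fall between 9.1 and 9.7. That estimate means an expected step of a number 0.12 log units higher from compound 3 to compound 4 (within the scatter).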

Compound 4, acid dissociation constant: 9.47
Beside the measured number, compound 4's estimate is 0.07 log units below it; the range from low to high includes it.
By their numbers in this assay, from the lowest: compounds 3, 1, 2 and 4 (each within the scatter of the next).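

In this assay, a fourth group on this aromatic carbon again stays within the scatter of all three earlier compounds: the exchange of 3-(dimethylamino)phenoxy (a number 0.19 log units higher from compound 3 to compound 4 (within the scatter)), the exchange of 4-fluorobenzyl (no change at the digits printed from compound 2 to compound 4 (within the scatter)) and the exchange of trifluoromethyl for methoxy (no change at the digits printed from compound 1 to compound 4 (within the scatter)). That last pair is a new kind of comparison, since the aromatic ring stays in place and only the group it carries differs, and even this exchange leaves the printed digits as they were. Nothing available here gives a reason for this steadiness.

All four groups shown contain one six-membered aromatic ring of carbon only. On these data alone, whether a group without such a ring, such as a carboxylic acid or an aliphatic amine, would also stay within the scatter on this carbon remains open.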